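The compounds below may be only part of what the source reports. "The series", "measured", "known", "first", "only" and "open" are said of these compounds alone.

Measured so far in a functional assay on MCF7 cells (Homo sapiens) for cytotoxicity, read by MTT assay, with a stated time of 24 h; on this read-out lower numbers stand for stronger inhibition and higher numbers for weaker inhibition: compound 1 `Cn1nc(-c2nnc(SCc3c(F)cccc3F)o2)cc1-c1ccc(C(F)(F)F)cc1` gives 26200 nM; compound 2 `Cn1nc(-c2nnc(SCc3ccc(Cl)cc3F)o2)cc1-c1ccc(C(F)(F)F)cc1` gives 18200 nM; compound 3 `Cn1nc(-c2ccc(C(F)(F)F)cc2)cc1-c1nnc(SCCOc2ccccc2F)o1` gives 33300 nM.

Compound 3 is not set apart on these numbers: its gap to compound 1 and its gap to compound 2 both fall within the scatter, so the three values read as one level.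

Compound 4 `Cn1nc(-c2ccc(C(F)(F)F)cc2)cc1-c1nnc(SCc2ccc(C(F)(F)F)cc2)o1` differs from compound 3 by 4-(trifluoromethyl)phenyl in place of (2-fluorophenoxy)methyl on a saturated chain carbon bound to a sulfur. Among the compounds with values here, the only measured step at this place is a 1.4-fold lower number from compound 1 to compound 2 (0.16 log units; within the scatter), which stayed within the scatter, and the values of compound 1, compound 2 and compound 3 together suggest that substituents on this chain carbon barely move the read-out. In this assay the step of a 1.4-fold lower number from compound 3 to compound 4 (0.14 log units; within the scatter) is therefore expected to stay within the scatter, with no clear direction. Compound 4 is estimated at 24000 nM, range 9000 nM to 60000 nM.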

Compound 4, half-maximal inhibitory concentration: 27100 nM
For compound 4 the middle estimate is 1.1-fold (0.05 log units) below the measured one, and the stated range covers the measured number.
By their numbers in this assay, from the lowest: compounds 2, 1, 4 and 3 (each within the scatter of the next).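

In this assay, a change much larger than the earlier exchange of ring substituents leaves the read-out at one level, with a 1.2-fold lower number from compound 3 to compound 4 (0.09 log units; within the scatter). On this pair, the 2-(2-fluorophenoxy)ethyl and 4-(trifluoromethyl)benzyl groups cannot be told apart, even though the hydrogen-bond acceptor of the leaving group is gone. No supporting measurement bears on why the read-out stays level.

All four compounds carry an aromatic ring of carbon only in this side chain. As far as these compounds go, whether an amine or a carboxylic acid in its place would move the number remains open.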